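From 3,4-dimethoxyphenyl to 3,5-dimethoxyphenyl in growth inhibition

The compounds below may be only part of what the source reports. "The series", "measured", "known", "first", "only" and "open" are said of these compounds alone.

In a functional assay on SH-SY5Y cells (Homo sapiens) for antiproliferative activity, read by MTT assay, with a stated time of 48 h (on this read-out higher numbers stand for weaker inhibition of growth and lower numbers for stronger inhibition of growth), compound 1 `COc1ccc(Cn2cnc3c(N(C)c4ccc(OC)cc4)nc(Cl)nc32)cc1` gives 31000 nM, while compound 2 `COc1ccc(N(C)c2nc(Cl)nc3c2ncn3Cc2ccc(OC)c(OC)c2)cc1` gives 7300 nM. Compound 2 therefore holds the lower of the two numbers and is the stronger growth inhibitor of this pair. Compound 3 `COc1ccc(N(C)c2nc(Cl)nc3c2ncn3Cc2cc(OC)cc(OC)c2)cc1` has the same atoms as compound 2, joined differently: 3,5-dimethoxyphenyl in place of 3,4-dimethoxyphenyl on a saturated chain carbon bound to an aromatic nitrogen.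

Among the compounds with values here, only one measured step bears on this change. It is a 4.2-fold lower number from compound 1 to compound 2 (0.63 log units; beyond the scatter), a modest move beyond the scatter, made by methoxy in place of hydrogen on an aromatic carbon. That step alters the number of methoxy groups, whereas compound 3 and compound 2 carry the same groups in a different arrangement. Within the data shown here, no measured pair shows such a rearrangement, so the data give no firm direction for it. A shift larger than the one from adding a methoxy is not expected, and a slight rise in this assay is the tentative guess. The expected result is a 1.2-fold higher number from compound 2 to compound 3 (0.09 log units; within the scatter), which would lie within the scatter. For compound 3 the estimated value is 9000 nM, with an expected range of 3000 nM to 27000 nM.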

Compound 3, concentration for 50% growth inhibition: > 100000 nM
Compound 3 gave a limit, no number; the forecaster's own chance of this, stated with the estimate: 10%; middle value at least 11-fold (1.04 log units) away from the limit.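

In this assay, within the data shown here, the arrangement of the two methoxy groups matters far more than the earlier compounds could show: 3,5-dimethoxyphenyl in place of 3,4-dimethoxyphenyl on a saturated chain carbon bound to an aromatic nitrogen gives an at least 13-fold higher number from compound 2 to compound 3 (1.13 log units; beyond the scatter), although the groups counted stay the same. The gain in growth inhibition seen on adding a methoxy thus holds for the 3,4-dimethoxyphenyl group but not for the 3,5-dimethoxyphenyl group, which also falls behind the 4-methoxyphenyl group, with an at least 3.2-fold higher number from compound 1 to compound 3 (0.50 log units; beyond the scatter). Compound 3 gives a limit and not a number, so both steps are minimum sizes and their full extent stays unknown: the limit of > 100000 nM in this assay, at which 1 of the 3 values shown sits.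

The compounds shown leave open whether this sharp dependence on arrangement is specific to methoxy groups, since a phenyl carrying ethoxy or hydroxyl groups in the same two arrangements could behave differently. They also leave open how a plain phenyl on that carbon would compare with the 4-methoxyphenyl and 3,4-dimethoxyphenyl groups, and whether the same contrast would appear on any core other than the shared one.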